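The source may hold more compounds than are shown below. What is called first, only, known or untested is meant among the compounds shown, and "the series" means these compounds.

Measured so far:
- compound 1 `COc1ccc(C2=C(c3ccc(SC)cc3)CC3CCCN3C2=O)cc1Br` gives 600 nM
- compound 2 `CSc1ccc(C2=C(c3ccc(C)c(C)c3)C(=O)N3CCCC3C2)cc1` gives 300 nM

Both values come from a functional assay on A498 cells (Homo sapiens) for cytotoxicity; a lower number here means a stronger inhibitor of growth, a higher number a weaker inhibitor of growth. Compound 2 has a single measured neighbour, compound 1, and the two values lie within the scatter of each other, so the numbers do not separate them.

Compound 3 `CSc1ccc(C2=C(c3ccc(F)c(C)c3)C(=O)N3CCCC3C2)cc1` has yet to be measured. It carries fluoro in place of methyl on an aromatic carbon, ortho to a methyl group and para to a large group, so that 3,4-dimethylphenyl becomes 4-fluoro-3-methylphenyl (fluoro in place of methyl on an aromatic carbon).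

Going by the values given here, only one measured step bears on this change. It is a 2.0-fold lower number from compound 1 to compound 2 (0.30 log units; within the scatter), which came with 3,4-dimethylphenyl in place of 3-bromo-4-methoxyphenyl on a double-bonded ring carbon and stayed within the scatter. That step altered the same aryl group more heavily than the present swap does, yet it gives no sign of a large shift. No direct fluoro and methyl pair has been measured, so no direction can be argued, and nothing beyond the scatter is expected in this assay.

The expected step, a 1.2-fold higher number from compound 2 to compound 3 (0.07 log units; within the scatter), is accordingly small. For compound 3 the estimated value is 350 nM, with an expected range from 130 nM to 900 nM.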

Compound 3, concentration for 50% growth inhibition: 300 nM
Estimate against measurement, compound 3: 1.2-fold (0.07 log units) above; the measured number falls inside the stated range.
By their numbers in this assay, from the lowest: compounds 2, 3 and 1 (each within the scatter of the next).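

In this assay, fluoro in place of methyl on the aromatic carbon ortho to a methyl group and para to a large group gives no change at the digits printed from compound 2 to compound 3 (within the scatter). Going by these compounds alone, this is the first reading of a change at this one atom alone, as the earlier step had replaced the whole aryl group. The wider exchange of 3-bromo-4-methoxyphenyl for 4-fluoro-3-methylphenyl gives a 2.0-fold lower number from compound 1 to compound 3 (0.30 log units; within the scatter), so the three aryl groups now compared are not separated by the numbers. No measurement bears on why this change leaves the number where it is.

The compounds shown leave open whether an amine, a carboxylic acid or a longer chain such as propyl on this aromatic carbon would also stay within the scatter, as fluoro and methyl are the only two groups compared there alone. They also leave open what a change of the methylthio group, which all three compounds share, would do in this assay.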